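The compounds below may be only part of what the source reports. "The series", "measured", "known", "first", "only" and "open" are said of these compounds alone.

Working notes on the series. In a functional assay on A2780 cells (Homo sapiens) for antiproliferative activity, read by MTT assay, with a stated time of 72 h (on this read-out lower numbers stand for stronger inhibition and higher numbers for weaker inhibition), compound 1 (`O=C(c1cc2ccccc2o1)N1N=C(c2ccc(Cl)cc2)CC1c1ccc(Cl)cc1`) gives a number (8.5 ug/mL), compound 2 (`O=C(c1cc2ccccc2o1)N1N=C(c2ccc(Cl)cc2)CC1c1ccccc1Cl`) gives a number (44.8 ug/mL) and compound 3 (`COc1ccc(C2CC(c3ccc(Cl)cc3)=NN2C(=O)c2cc3ccccc3o2)cc1OC`) gives a number (6.29 ug/mL). Compound 3 sits at the low end of the three numbers, but it shares that end with one neighbour (a 1.4-fold lower number from compound 1 to compound 3 (0.13 log units; within the scatter)) and stands clear only of the other (a 7.1-fold lower number from compound 2 to compound 3 (0.85 log units; beyond the scatter)).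

Compound 4 (`COc1ccc(C2CC(c3ccc(F)cc3)=NN2C(=O)c2cc3ccccc3o2)cc1OC`) keeps the 3,4-dimethoxyphenyl group of compound 3. The change is 4-chlorophenyl to 4-fluorophenyl (fluoro in place of chloro on an aromatic carbon), fluoro in place of chloro on an aromatic carbon, para to a large group.

All measured steps vary the group on a saturated ring carbon, and none exchanges this halogen, so they bear only indirectly. Replacing 4-chlorophenyl with 2-chlorophenyl at that other place gave a modest step (a 5.3-fold higher number from compound 1 to compound 2 (0.72 log units; beyond the scatter)), while replacing it with 3,4-dimethoxyphenyl stayed within the scatter (a 1.4-fold lower number from compound 1 to compound 3 (0.13 log units; within the scatter)). For a single halogen exchange at the new place, no step beyond the scatter is expected, and the data assign no direction. The expected change is small (a 1.1-fold higher number from compound 3 to compound 4 (0.05 log units; within the scatter)). Compound 4 is estimated at 7 ug/mL in this assay with an expected range from 3 ug/mL to 16 ug/mL around that estimate.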

Compound 4, half-maximal inhibitory concentration: > 50 ug/mL
Compound 4: no number, only a limit (the forecaster's own chance of this, stated with the estimate: 2%); middle value at least 7.1-fold (0.85 log units) from the limit.
By their numbers in this assay, from the lowest: compounds 3 and 1 (each within the scatter of the next); then compound 2. At a limit, above all of these: compound 4.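

In this assay compound 4 gives > 50 ug/mL, which is a limit of the assay and not a number. Within the data shown here, with the 3,4-dimethoxyphenyl group held fixed, fluoro in place of chloro on an aromatic carbon, para to a large group, gives an at least 7.9-fold higher number from compound 3 to compound 4 (0.90 log units; beyond the scatter), so this halogen place is not indifferent: a single-atom exchange here moves the read-out beyond the scatter, which the earlier steps, all made on the saturated ring carbon, could not show, and the size of this step is known only from one side. The chloro of compound 3 therefore goes with a measurable number in this series, while the fluoro of compound 4 is the one case that reaches the top of the range, and the reading rests on that single compound: the limit of > 50 ug/mL in this assay, at which 1 of the 4 values shown sits.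

From the compounds shown here alone, whether the exchange behaves the same way with the 4-chlorophenyl group of compound 1 or the 2-chlorophenyl group of compound 2 on the saturated ring carbon stays open. Also open, going by these compounds, is how bromo, methyl or an amine would read at this halogen place, and so whether chloro is a special case or one of several groups that keep a number.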